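Predicting Lipophilicity After a Repeated Chain Substitution

This account rests on a few compounds, and the source may have more. Where it says the series, first, only, none or still open, it means among the compounds named here.

The measured compounds:

Compound 1, `CCOC(=O)/C=C(C)/C=C/CC(C)CCCC(C)(C)SC`, gives 6.36 in a physicochemical assay for lipophilicity; a lower number here means a more polar compound, a higher number a more lipophilic compound.
Compound 2, `CCNC(=O)OC(C)(C)CCCC(C)C/C=C/C(C)=C/C(=O)OCC`, gives 5.65 in this assay.
Compound 3, `CSC(C)(C)CCCC(C)C/C=C/C(C)=C/C(=O)OC(C)C`, gives 6.77 in this assay.

Compound 4, `CCNC(=O)OC(C)(C)CCCC(C)C/C=C/C(C)=C/C(=O)OC(C)C`, is not yet measured in this assay.

Compounds 1 and 2 differ in one place: (ethylcarbamoyl)oxy in place of methylsulfanyl on a saturated chain carbon bound to three saturated chain carbons. That change gave a number 0.71 log units lower from compound 1 to compound 2 (beyond the scatter). Compound 3 stands apart from compound 1 in another place: methyl in place of hydrogen on a saturated chain carbon bound to an oxygen next to a carbonyl group and a saturated chain carbon. That change gave a number 0.41 log units higher from compound 1 to compound 3 (beyond the scatter), so compound 3 carries the highest of the three values.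

Compound 4 is related to compound 3 in the same way that compound 2 is related to compound 1: (ethylcarbamoyl)oxy in place of methylsulfanyl on a saturated chain carbon bound to three saturated chain carbons. The place is described in the same words in both pairs, so this is the same change made on two cores that differ only as described above. Since the two cores differ only by the methyl to hydrogen difference, the expectation is that the step in this assay will be about the size seen before, a number 0.71 log units lower from compound 1 to compound 2 (beyond the scatter), and the step from compound 3 to compound 4 is expected to be a number 0.71 log units lower from compound 3 to compound 4 (beyond the scatter). Compound 4 is accordingly estimated at 6.06, with a likely range from 5.7 to 6.4. Measurement will show how the number actually lands.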

Compound 4, partition coefficient: 6.06
For compound 4 middle estimate and measured number coincide at the digits printed; the range from low to high includes it.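

In this assay, (ethylcarbamoyl)oxy in place of methylsulfanyl gave a number 0.71 log units lower from compound 3 to compound 4 (beyond the scatter) and also a number 0.71 log units lower from compound 1 to compound 2 (beyond the scatter) on the other core, so this step has the same size on both cores, while methyl in place of hydrogen gave a number 0.41 log units higher from compound 2 to compound 4 (beyond the scatter) and also a number 0.41 log units higher from compound 1 to compound 3 (beyond the scatter) so that the two changes simply add up across these four compounds. This is a single transfer between two cores that differ by one methyl, so it shows that the change carried over here, but it does not show that the step would keep its size on a core that differs more, or across the rest of the series. Nothing measured here accounts for the size of either step, and the match between the pairs gives no cause for it.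

The compounds shown leave open how the number would move if an amine or a carboxylic acid entered on that saturated chain carbon in place of methylsulfanyl, or if a longer chain sat on the carbon bound to the oxygen. They also leave open whether the two changes would still add up once either of those groups is present, since every pair here draws on the same two changes.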